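Swapping Chloro for Methyl: What to Expect of Compound 3

The source may report more compounds than this note shows. Statements on the series, on what has been measured and on what is new or still open speak of the compounds shown alone.

Measured so far:
Compound 1, `C=Cc1ccc(S(=O)(=O)Nc2ccc3oc(-c4ccccc4)nc3c2)cc1`: 53000 nM
Compound 2, `O=S(=O)(Nc1ccc(-c2nc3ccccc3o2)cc1)c1cccc(Cl)c1`: > 100000 nM

Of the compounds shown here, two have been tested in an ADME assay on HEK293 cells (Homo sapiens) for cytotoxicity, read by resazurin assay, with a stated time of 48 h; on this read-out higher numbers stand for lower toxicity in this test and lower numbers for higher toxicity in this test. Compound 1 gives a measured number, 53000 nM. Compound 2 gives only a limit of the test, not a number: it sits at the limit of > 100000 nM in this assay, at which 1 of the 2 values shown sits. So for compound 2 nothing more is known than that bound.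

Compound 3, `Cc1cccc(S(=O)(=O)Nc2ccc(-c3nc4ccccc4o3)cc2)c1`, differs from compound 2 in a single place: methyl in place of chloro on an aromatic carbon. Among the compounds with values here, no measured pair among the tested compounds shows what this exchange does, so the expectation rests on compound 2 alone. The step in this assay is expected to be a number no higher from compound 2 to compound 3 (the limit leaves the size open), that is, no change beyond the usual scatter in either direction. Compound 3 is therefore expected to land at about 100000 nM, with a range from 40000 nM to 300000 nM, and it may well again be reported only as a limit rather than a number.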

Compound 3, half-maximal cytotoxic concentration: > 100000 nM
Compound 3: a limit, no number; the forecaster's own chance of this, stated with the estimate: 60%; the middle value lies on the limit itself.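

Compound 2 and compound 3 both give a limit rather than a number in this assay, so no step between them can be read: the limit of > 100000 nM in this assay, at which 2 of the 3 values shown sit.

Going by these compounds, what methyl in place of chloro does in this assay stays open, as does how far beyond the limit either compound lies.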